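The source may hold more compounds than are shown below. What is called first, only, known or untested is meant among the compounds shown, and "the series" means these compounds.

Measured so far:
compound 1, `CC(=O)OCCOCn1cnc2c(Cl)nc(N)nc21`: 91 ug/mL in a functional assay on L1210 cells (Mus musculus) for inhibition; a lower number here means a stronger inhibitor, a higher number a weaker inhibitor
compound 2, `Nc1nc2c(nc(Br)n2COCCO)c(=O)[nH]1`: 355 ug/mL in this assay

Of the two numbers, compound 2 gives the higher one, a weaker inhibitor than compound 1 by a gap beyond the scatter. Compound 3, `Nc1nc2c(nc(N)n2COCCO)c(=O)[nH]1`, is not yet measured; it differs from compound 2 as amino in place of bromo on an aromatic carbon. Among the measured compounds shown here, no measured pair shows this change, so no step size is known from the data. A modest step in a 1.1-fold higher number from compound 2 to compound 3 (0.05 log units; within the scatter) is expected, quite possibly none beyond the scatter. For compound 3 the estimate in this assay is 400 ug/mL, within 150 ug/mL to 1000 ug/mL.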

Compound 3, concentration for 50% inhibition: > 500 ug/mL
Compound 3: a limit, no number; the forecaster's own chance of this, stated with the estimate: 25%; at least 1.2-fold (0.09 log units) between middle value and limit.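

In this assay, compound 3 gives a limit and not a number: the limit of > 500 ug/mL in this assay, at which 1 of the 3 values shown sits.

Amino in place of bromo on this aromatic carbon, between two ring nitrogen atoms, gives an at least 1.4-fold higher number from compound 2 to compound 3 (0.14 log units; that floor lies within the scatter), so the step can be read only as a floor. The change brings no measurable gain in inhibition, yet a real loss is not established either.

Still open, as far as these compounds go, is whether methyl or methylamino on this carbon would give a number rather than a limit. The true size of the step from bromo to amino also stays unresolved.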